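A few compounds are considered here, and "the series" means these few. Any claim that something is new, unique, unknown or untested is made for them only; others in the source may bear on it.

In a functional assay, with a stated time of 6 min (on this read-out higher numbers stand for weaker inhibition and lower numbers for stronger inhibition), compound 1 `S=c1oc(-c2ccc3c(c2)OCCO3)nn1CNC1CCCCC1` gives 18400 nM, compound 2 `Fc1cccc(NCn2nc(-c3ccc4c(c3)OCCO4)oc2=S)c1` gives 6620 nM, and compound 3 `Fc1cc(NCn2nc(-c3ccc4c(c3)OCCO4)oc2=S)cc(F)c1F` gives 2920 nM, the lowest of these three numbers. Compound 4 `S=c1oc(-c2ccc3c(c2)OCCO3)nn1CNc1cccc(Cl)c1` carries 3-chlorophenyl in place of 3,4,5-trifluorophenyl on an amine nitrogen. The closest guide is a 2.3-fold lower number from compound 2 to compound 3 (0.36 log units; beyond the scatter), where 3,4,5-trifluorophenyl replaced 3-fluorophenyl. The replacements of cyclohexyl, a 2.8-fold lower number from compound 1 to compound 2 (0.44 log units; beyond the scatter) and a 6.3-fold lower number from compound 1 to compound 3 (0.80 log units; beyond the scatter), were also modest. Among the compounds with values here, no measured compound carries chlorine, so the expectation is loose, but a modest step towards a higher number is expected in this assay. The estimated change is a 1.7-fold higher number from compound 3 to compound 4 (0.23 log units; within the scatter). For compound 4 the estimated value is 5000 nM, with an expected range from 2200 nM to 11500 nM.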

Compound 4, half-maximal inhibitory concentration: 6220 nM
For compound 4 the middle estimate is 1.2-fold (0.09 log units) below the measured one, within the range that was stated.
By their numbers in this assay, from the lowest: compound 3; then compounds 4 and 2 (each within the scatter of the next); then compound 1.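

In this assay, chloro in place of fluoro on an aromatic carbon gives no readable change (a 1.1-fold lower number from compound 2 to compound 4 (0.03 log units; within the scatter)), so 3-chlorophenyl and 3-fluorophenyl cannot be told apart here. The gain of 3,4,5-trifluorophenyl therefore holds against a second singly halogenated ring (a 2.1-fold higher number from compound 3 to compound 4 (0.33 log units; beyond the scatter)), while 3-chlorophenyl, like the other aryl groups, gives a lower number than cyclohexyl (a 3.0-fold lower number from compound 1 to compound 4 (0.47 log units; beyond the scatter)). Nothing available explains these steps.

As far as these compounds go, whether an unsubstituted phenyl or a methoxyphenyl would fall with these groups stays open. So does the effect of a trichlorophenyl on the amine nitrogen.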